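The source may hold more compounds than are shown below. What is called first, only, known or untested is meant among the compounds shown, and "the series" means these compounds.

Compound 1 `COc1cc2c(c(O)c1C(=O)/C=C/c1ccc(OC(=O)C3CCC3)cc1)CCC(C)(C)O2` and compound 2 `COc1cc2c(c(O)c1C(=O)/C=C/c1ccc(OC(=O)c3ccccc3F)cc1)CCC(C)(C)O2` share one core and differ only in the group on a carbonyl carbon. In an assay on HEK293T cells for inhibition of nuclear factor NF-kappa-B complex (Homo sapiens), read by a luciferase reporter (on this read-out lower numbers stand for stronger inhibition and higher numbers for weaker inhibition), compound 1 gives > 30000 nM, which is a limit of the assay and not a number. In this assay compound 2 gives > 30000 nM, again a limit rather than a number. The step that the two limits leave unreadable from compound 1 to compound 2 therefore stays unreadable, since both ends sit at the limit of > 30000 nM in this assay, at which 2 of the 2 values shown sit. Compound 3 `COc1cc2c(c(O)c1C(=O)/C=C/c1ccc(OC(C)=O)cc1)CCC(C)(C)O2` has not yet been measured; it differs from compound 2 by methyl in place of 2-fluorophenyl on a carbonyl carbon. For the measured compounds named here, the only measured step that bears on this kind of change is the one from compound 1 to compound 2, and it yields neither a size nor a direction. For compound 3 the step of a number no higher from compound 2 to compound 3 (the limit leaves the size open) is expected to lie within the scatter, with a limit the most likely outcome in this assay. The estimate for compound 3 is 30000 nM, with a range of 10000 nM to 100000 nM.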

Compound 3, half-maximal inhibitory concentration: > 30000 nM
Compound 3: only a limit was reported (the forecaster's own chance of this, stated with the estimate: 75%); the middle value lies on the limit itself.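

In this assay compound 3 gives > 30000 nM as a limit of the assay and not a number, so the steps among compound 1, compound 2 and compound 3 cannot be read: the limit of > 30000 nM in this assay, at which 3 of the 3 values shown sit.

The compounds shown leave open whether cyclobutyl, 2-fluorophenyl and methyl on a carbonyl carbon differ at all in inhibition.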